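From isopropyl to 1-hydroxyethyl in a growth inhibition series

The source may hold more compounds than are shown below. What is called first, only, known or untested is meant among the compounds shown, and "the series" means these compounds.

In a functional assay on T47D cells (Homo sapiens) for antiproliferative activity, read by sulforhodamine B assay, with a stated time of 48 h (on this read-out lower numbers stand for stronger inhibition of growth and higher numbers for weaker inhibition of growth), compound 1 (`CCCCCCCCC[C@@H](O)[C@@H](N)[C@@H](C)CC`) gives 14000 nM and compound 2 (`CCCCCCCCC[C@@H](O)[C@@H](N)C(C)C`) gives 17000 nM on the same read-out, so compound 2 stands level with compound 1 within the scatter. Compound 3 (`CCCCCCCCC[C@@H](O)[C@@H](N)[C@@H](C)O`) has not yet been measured. Its difference from compound 2 is 1-hydroxyethyl in place of isopropyl on a saturated chain carbon bound to an amine nitrogen and a saturated chain carbon and this puts 1-hydroxyethyl in place of isopropyl on a saturated chain carbon bound to an amine nitrogen and a saturated chain carbon. For the measured compounds named here, only one measured step bears on this change, and only indirectly. That step, a 1.2-fold higher number from compound 1 to compound 2 (0.08 log units; within the scatter) in this assay for hydrogen in place of methyl, stays small, but it replaces carbon with hydrogen and brings in no oxygen. Going by the values given here, no measured compound carries a hydroxyl in this group, so the expectation remains loose. The expected step is a 1.1-fold higher number from compound 2 to compound 3 (0.02 log units; within the scatter) and no change beyond the scatter is expected. For compound 3 the estimate is 18000 nM with an expected range from 7000 nM to 45000 nM in this assay once it is tested.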

Compound 3, concentration for 50% growth inhibition: 16000 nM
Beside the measured number, compound 3's estimate is 1.1-fold (0.05 log units) above it; low and high end bracket the measured number.
By their numbers in this assay, from the lowest: compounds 1, 3 and 2 (each within the scatter of the next).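

In this assay, for the compounds shown here, the change from isopropyl to 1-hydroxyethyl on a saturated chain carbon bound to an amine nitrogen and a saturated chain carbon brings oxygen into this group for the first time, with a hydrogen-bond donor and a hydrogen-bond acceptor, and gives a 1.1-fold lower number from compound 2 to compound 3 (0.03 log units; within the scatter). The other single change that leads to the same structure, hydroxy in place of ethyl on a saturated chain carbon bound to two saturated chain carbons, gives a 1.1-fold higher number from compound 1 to compound 3 (0.06 log units; within the scatter), so this position, earlier probed only by hydrogen in place of methyl, now also accepts a hydroxyl with no step beyond the scatter. Nothing available explains why these values stay level.

As far as these compounds go, because all three compounds lie within the scatter of their neighbours, it remains open whether any group at this position can shift growth inhibition at all, and an amine, a carboxylic acid or a longer chain there would test that. From the compounds shown here alone, the 1-hydroxyethyl group also enters with one defined stereocentre, so its opposite arrangement and a methoxy group in place of the hydroxyl remain open as well.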